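The source may report more compounds than this note shows. Statements on the series, on what has been measured and on what is new or still open speak of the compounds shown alone.

Measured compounds:
- compound 1, `Cc1cc(CNC(=O)CCc2ccc(C(C)(C)C)cc2)cc(C)c1NS(C)(=O)=O`, gives 620 nM in a functional assay for antagonist activity at transient receptor potential cation channel subfamily V member 1 (Rattus norvegicus); on this read-out lower numbers stand for stronger inhibition and higher numbers for weaker inhibition
- compound 2, `C=Cc1cc(CNC(=O)CCc2ccc(C(C)(C)C)cc2)cc(F)c1NS(C)(=O)=O`, gives 25 nM in this assay
- compound 3, `CC(C)(C)c1ccc(CCC(=S)NCc2ccc(NS(C)(=O)=O)c(F)c2)cc1`, gives 40 nM in this assay

Among these three numbers compound 3 stands second highest. Its nearest neighbour is compound 2, whose number is somewhat lower but within the scatter of repeated measurement, so the two values cannot be ranked against each other. The furthest is compound 1, whose number is far higher and beyond the scatter. Compound 4, `CC(C)(C)c1ccc(CCC(=S)NCc2ccc(NS(C)(=O)=O)c(Cl)c2)cc1`, has not yet been measured. It differs from compound 3 in one place: chloro in place of fluoro on an aromatic carbon, the chlorine sitting on an aromatic carbon of a six-membered aromatic ring of carbon only, ortho to a methanesulfonamido group and meta to a large group. For the measured compounds named here, no measured pair in this set shows the effect of such a swap, so no step size can be read off. With both groups being single heavy atoms without donors or acceptors, the step from compound 3 to compound 4 is expected to stay within the scatter, no change at the digits printed from compound 3 to compound 4 (within the scatter). Compound 4 is therefore estimated at 40 nM, between 15 nM and 110 nM.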

Compound 4, half-maximal inhibitory concentration: 96 nM
For compound 4 the middle estimate is 2.4-fold (0.38 log units) below the measured one; the measured number falls inside the stated range.
By their numbers in this assay, from the lowest: compounds 2 and 3 (each within the scatter of the next); then compound 4; then compound 1.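

In this assay, chloro in place of fluoro on an aromatic carbon, ortho to a methanesulfonamido group, gives a 2.4-fold higher number from compound 3 to compound 4 (0.38 log units; beyond the scatter), a modest step but one beyond the scatter. For the compounds shown here, none of the earlier compounds isolated this position, and this pair shows that exchanging one single heavy atom for another here can shift the read-out, even though the count of hydrogen-bond donors and acceptors stays the same. No measurement of any other property bears on this step, so it stands without an explanation.

The compounds shown leave open how bromo, methoxy or a nitrile at this position would compare with fluoro and chloro. They also leave open whether the same swap would give a step of similar size with a carbonyl, as in compound 2, instead of the thiocarbonyl.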